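The source may report more compounds than this note shows. Statements on the series, on what has been measured and on what is new or still open speak of the compounds shown alone.

Measured compounds:
compound 1 `CCNC(=O)/C=C(C)/C=C/C=C(C)/C=C/c1c(C)cc(OC)c(C)c1C`: 11%
compound 2 `COc1cc(C)c(/C=C/C(C)=C(F)/C=C/C(C)=C/C(=O)O)c(C)c1C`: 30%

Of the compounds shown here, two have been measured in a functional assay on the whole organism (strain Hart Swiss) with Mus musculus as the target, with stated times of 5 days and 2 weeks, at a dose of 5 mg/kg by the intraperitoneal route; on this read-out lower numbers stand for a weaker effect and higher numbers for a stronger effect at the one dose given. Compound 1 gives 11%, while compound 2 gives 30%. Among the compounds with values here, of the two numbers, compound 2 stands highest; its only neighbour is compound 1, whose value lies lower by a gap that is beyond the usual scatter.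

Compound 3 `COC(=O)/C=C(C)/C=C/C(F)=C(C)/C=C/c1c(C)cc(OC)c(C)c1C` has not yet been measured. It differs from compound 2 in a single place: methyl in place of hydrogen on an oxygen next to a carbonyl group. Within the data shown here, no pair of measured compounds carries this same change, so the two numbers at hand say nothing directly about what it does. Without such a precedent, the step from compound 2 is expected to be none beyond the scatter, in either direction, as no change at the digits printed from compound 2 to compound 3 (within the scatter) describes. Compound 3 is therefore estimated to give 30% in this assay, with a range from 10% to 55%.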

Compound 3, a percentage reported as activity, at one dose (the size of the read-out at that dose, not a potency): 28%
Beside the measured number, compound 3's estimate is 2 percentage points above it; the range from low to high includes it.
By their numbers in this assay, from the lowest: compound 1; then compounds 3 and 2 (each within the scatter of the next).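

In this assay, exchanging hydrogen for methyl on the oxygen next to the carbonyl group, which turns carboxy into methoxycarbonyl, gives a number 2 percentage points lower from compound 2 to compound 3 (within the scatter). Within the data shown here, this is the first reading of a single change at this place, and at the one dose given the two groups cannot be told apart, so in this pair the hydrogen on that oxygen is not needed for the effect to stand at this level. Nothing measured here offers an explanation for this outcome.

As far as these compounds go, it remains open whether a larger ester, such as a butyl ester, or a hydroxamic acid in place of the carboxy group would also stay within the scatter. The single dose also leaves open whether compound 2 and compound 3 would still match at other doses.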